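Swapping bromine for an amino group on a weak inhibitor

The compounds below may be only part of what the source reports. "The series", "measured", "known", "first", "only" and "open" are said of these compounds alone.

Of the compounds shown here, three sharing one core have been tested in a functional assay on HCT-116 cells (Homo sapiens) for inhibition, read by MTT assay, with a stated time of 48 h; a higher number here means a weaker inhibitor, a lower number a stronger inhibitor. Compound 1 `COc1ccc(CN(C(=O)CCl)c2cc(OC)c(OC)c(OC)c2)cc1O` gives 250 nM. Compound 3 `C/C=C/C(=O)N(Cc1ccc(OC)c(Br)c1)c1cc(OC)c(OC)c(OC)c1` gives 2800 nM. Compound 2 `COc1ccc(CNc2cc(OC)c(OC)c(OC)c2)cc1Br` gives 48100 nM, the highest number of the three, so it is the weakest inhibitor here; its nearest neighbour is compound 3, which differs only by carrying a (prop-1-en-1-yl)carbonyl in place of hydrogen on the nitrogen, a change that produced a 17-fold lower number from compound 2 to compound 3 (1.23 log units; beyond the scatter).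

The new compound 4 `COc1ccc(CNc2cc(OC)c(OC)c(OC)c2)cc1N` keeps the free nitrogen of compound 2 and changes only one position: amino in place of bromo on an aromatic carbon. Going by the values given here, no measured pair shows this exchange, and the one step that is known, from compound 2 to compound 3, alters a different part of the molecule. Compound 1 carries a hydroxyl at the corresponding carbon but also a different group on the nitrogen, so its value cannot be read as a guide to this single swap.

With nothing bearing directly on the change, the expectation for compound 4 is a step of a 1.2-fold lower number from compound 2 to compound 4 (0.08 log units; within the scatter), within the scatter. Compound 4 is therefore estimated at 40000 nM, with a likely range from 12000 nM to 130000 nM.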

Compound 4, half-maximal inhibitory concentration: 8270 nM
For compound 4 the middle estimate is 4.8-fold (0.68 log units) above the measured one; measured number below the stated range.
By their numbers in this assay, from the lowest: compound 1; then compound 3; then compound 4; then compound 2.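

Measured in this assay, amino in place of bromo on the aromatic carbon ortho to a methoxy group gives a 5.8-fold lower number from compound 2 to compound 4 (0.76 log units; beyond the scatter), so the group on this carbon matters even while the nitrogen stays free. Going by these compounds alone, the earlier compounds could not show this, since their only step, a 17-fold lower number from compound 2 to compound 3 (1.23 log units; beyond the scatter), changes the nitrogen and leaves this carbon alone. Nothing available explains why the number moves with this swap.

Still open, as far as these compounds go, is whether the same swap would have a similar effect with the (prop-1-en-1-yl)carbonyl on the nitrogen, as in compound 3. Also open, from the compounds shown here alone, is how other groups on this carbon, such as a dimethylamino group or a carboxylic acid, would compare with amino and bromo on the same core.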